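A few compounds are considered here, and "the series" means these few. Any claim that something is new, unique, unknown or untested is made for them only; others in the source may bear on it.

In a functional assay on HeLa cells (Homo sapiens) for inhibition, read by CCK-8 assay, with a stated time of 72 h, tested at 8 uM (a lower number here means less inhibition of growth, a higher number more inhibition of growth at the concentration tested), three compounds have been measured so far. Compound 2 `Nc1ccccc1NC(=O)/C=C/c1ccc(CSc2ccc(Cl)cc2)cc1` gives 17.3%, and compound 1 `Cc1cc(C)cc(SCc2ccc(/C=C/C(=O)Nc3ccccc3N)cc2)c1` gives 3.39%. The step of a number 13.9 percentage points lower from compound 2 to compound 1 (beyond the scatter) corresponds to the change (3,5-dimethylphenyl in place of 4-chlorophenyl on a sulfur). Compound 3 `Nc1ccccc1NC(=O)c1ccc(CSc2ccc(Cl)cc2)cc1` stands highest of the three, giving 51.4%. The difference between the core of compound 3 and the core of compound 2 is not broken down here.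

Compound 4 `Cc1cc(C)cc(SCc2ccc(C(=O)Nc3ccccc3N)cc2)c1` has not yet been measured in this assay. It differs from compound 3 by 3,5-dimethylphenyl in place of 4-chlorophenyl on a sulfur, the same change that leads from compound 2 to compound 1, at the same place. Among the measured compounds shown here, because the only earlier instance of this change a number 13.9 percentage points lower from compound 2 to compound 1 (beyond the scatter) lowered growth inhibition by a modest amount, a similar downward step is expected here. Compound 4 is therefore expected to show a step of a number 14.4 percentage points lower from compound 3 to compound 4 (beyond the scatter). This expectation rests on one pair alone, and the core of compound 3 differs from that of compound 2, so the outcome may not carry over exactly. Compound 4 is estimated at 37%, with a likely range from 20% to 52%.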

Compound 4, percent growth inhibition at one concentration: 78.9%
Compound 4: the middle estimate sits 41.9 percentage points below what was measured, outside the stated range (above it).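

In this assay, putting 3,5-dimethylphenyl in place of 4-chlorophenyl on a sulfur gives a number 27.5 percentage points higher from compound 3 to compound 4 (beyond the scatter), so the change does not keep its direction when carried to the core of compound 3, and the two cores give opposite outcomes: the same change on two cores in this assay, a number 13.9 percentage points lower (beyond the scatter) from compound 2 to compound 1 and a number 27.5 percentage points higher (beyond the scatter) from compound 3 to compound 4, 41.4 percentage points apart, beyond the scatter of two such steps

For this series, the step measured on one core therefore gave no reliable guide to the step on the other, and the effect of this change has to be read with its core. Two pairs do not show which part of the cores decides the direction, nor which direction the change would take on any further core.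

The compounds shown carry only these two groups on the sulfur, which leaves open how an amine, a carboxylic acid or a longer chain in that place would behave on either core. From the compounds shown here alone, each compound is also read at a single concentration, so it remains open whether the same order would hold at other concentrations.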